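This account rests on a few compounds, and the source may have more. Where it says the series, first, only, none or still open, it means among the compounds named here.

Measured compounds:
Compound 1 `COc1ccc(C(=O)OC(CCN(C)C)c2ccc(Cl)cc2)cc1`: in an assay on NIH3T3 cells with Urotensin-2 receptor (Homo sapiens) as the target (a lower number here means a smaller maximal response, a higher number a larger maximal response), compound 1 gives 84%.
Compound 2 `CN(C)CCC(OC(=O)c1ccc(C(F)(F)F)cc1)c1ccc(Cl)cc1`: in this assay compound 2 gives 47%.
Compound 3 `COc1ccc(C(=O)NC(CCN(C)C)c2ccc(Cl)cc2)cc1`: in this assay compound 3 gives 162%.

Compound 1 and compound 2 share one core and differ in a single place. The change is trifluoromethyl in place of methoxy on an aromatic carbon. The step it made is a number 37 percentage points lower from compound 1 to compound 2 (beyond the scatter).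

Compound 3 carries a different core. How the core of compound 3 differs from the core of compound 1 is not broken down here; the two differ in more than one place. Compound 3 stands highest of the three measured compounds, beyond the scatter to both compound 1 and compound 2.

Compound 4 `CN(C)CCC(NC(=O)c1ccc(C(F)(F)F)cc1)c1ccc(Cl)cc1` has not yet been measured in this assay. It is related to compound 3 by trifluoromethyl in place of methoxy on an aromatic carbon. This is the same change as the one from compound 1 to compound 2; among the compounds shown it occurs two times in all, and the place is described in the same words both times.

Whether the step on the core of compound 3 repeats the step seen on the core of compound 1 is the open question; only one earlier case exists, so the expectation rests on it alone. The step from compound 3 to compound 4 is estimated as a number 52 percentage points lower from compound 3 to compound 4 (beyond the scatter), because the earlier step was a number 37 percentage points lower from compound 1 to compound 2 (beyond the scatter) and compound 3 starts from 162%. For compound 4 the value in this assay is expected to be 110%, between 70% and 150%.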

Compound 4, largest response reached (reported as efficacy), in percent of the reference or control that the assay uses: 115%
Compound 4: the middle estimate sits 5 percentage points below what was measured, within the range that was stated.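

On the core of compound 3, trifluoromethyl in place of methoxy, on an aromatic carbon para to a large group, gave a number 47 percentage points lower from compound 3 to compound 4 (beyond the scatter) in this assay. The step therefore carried over from the core of compound 1 with the same direction and, within the scatter, the same size: the same change on two cores in this assay, a number 37 percentage points lower (beyond the scatter) from compound 1 to compound 2 and a number 47 percentage points lower (beyond the scatter) from compound 3 to compound 4, 10 percentage points apart, within the scatter of two such steps. This shows that, for these two matched pairs, the change lowered the maximal response by a comparable amount on either core, but it does not show why, nor does it show that the same would hold on any further core, at any other place on the ring, or for any read-out other than the largest response reached.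

The compounds shown leave open how other groups at this place would behave, for example a nitrile, a fluorine atom or a carboxylic acid in place of methoxy, and whether the step would persist with a longer chain carrying the amine. Among these compounds, they also leave open which part of the difference between the two cores goes with which place, as the cores differ in more than one place and no compound separates those differences.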